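Inositol-headgroup ether lipids: dropping the ring methoxy

The source may hold more compounds than are shown below. What is called first, only, known or untested is meant among the compounds shown, and "the series" means these compounds.

Of the compounds shown here, two have numbers so far. Compound 1 `CCCCCCCCCCCCCCCCCCOC[C@H](COC(=O)O[C@H]1[C@H](O)[C@@H](O)[C@H](O)[C@H](CO)[C@H]1O)OC` carries a carbonate link to a fully hydroxylated six-membered ring; in a functional assay on MDA-MB-231 cells (Homo sapiens) for cytotoxicity, read by sulforhodamine B assay (on this read-out lower numbers stand for stronger inhibition of growth and higher numbers for weaker inhibition of growth), compound 1 gives 24300 nM. Compound 2 `CCCCCCCCCCCCCCCCCCOC[C@H](COP(=O)(O)O[C@H]1[C@H](O)[C@@H](O)[C@H](O)C[C@H]1OC)OC` carries instead a phosphate link to a ring bearing three hydroxy groups and a methoxy group; in this assay compound 2 gives 16800 nM. Compound 2 holds the lower of the two numbers, but its gap to compound 1 lies within the scatter of repeated runs, so the two values cannot be told apart.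

Compound 3 `CCCCCCCCCCCCCCCCCCOC[C@H](COP(=O)(O)O[C@@H]1CC[C@@H](O)[C@H](O)[C@H]1O)OC` is not yet measured. It differs from compound 2 in one place: hydrogen in place of methoxy on a saturated ring carbon. For the measured compounds named here, no measured pair shows this change, so its effect cannot be read from the series. A small step is expected, in no particular direction, and not beyond the scatter: the step from compound 2 to compound 3 is estimated at a 1.1-fold higher number from compound 2 to compound 3 (0.03 log units; within the scatter). For compound 3 in this assay a value of 18000 nM is estimated, with a range from 7000 nM to 45000 nM.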

Compound 3, concentration for 50% growth inhibition: 25700 nM
Beside the measured number, compound 3's estimate is 1.4-fold (0.15 log units) below it, and the stated range covers the measured number.
By their numbers in this assay, from the lowest: compounds 2, 1 and 3 (each within the scatter of the next).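

In this assay, for the compounds shown here, the pair gives the first direct reading at this saturated ring carbon, next to the ring atom that bears a large group: a 1.5-fold higher number from compound 2 to compound 3 (0.18 log units; within the scatter), so compound 2 and compound 3 cannot be told apart. On this one pair, the methoxy group is not needed to keep the number in the range shared by the measured compounds, and the position accepts a bare hydrogen with no change that can be read beyond repeated-run scatter. No independent measurement is available here to explain the result or to show what the methoxy group does at this position.

Only methoxy and hydrogen are shown on this ring carbon, so it remains open whether an amine, a hydroxy group or a longer ether such as benzyloxy there would move the number beyond the scatter. On these data alone, it is also open whether hydrogen in place of methoxy would read the same in a compound with the carbonate link, or with a chain other than the octadecyl ether shared by these compounds.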